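A Benzyl Group Replaces a Larger Substituent at the Assay Limit

The compounds below may be only part of what the source reports. "The series", "measured", "known", "first", "only" and "open" are said of these compounds alone.

Of the compounds shown here, three sharing one core have been tested in a toxicity assay on HT-29 cells (Homo sapiens) for cytotoxicity; on this read-out higher numbers stand for lower toxicity in this test and lower numbers for higher toxicity in this test. Compound 1 (`CCCn1nc(C(=O)N[C@H]2COc3ccccc3N(C)C2=S)nc1Cc1ccccc1`) reads > 100000 nM, which is a limit of the assay and not a number. Compound 2 (`CN1C(=S)[C@@H](NC(=O)c2nc(Cc3ccccc3)n(CCCCCC#N)n2)COc2ccccc21`) reads > 100000 nM, again a limit. Compound 3 (`CN1C(=S)[C@@H](NC(=O)c2nc(Cc3ccccc3)n(C3CCN(C(=O)OC(C)(C)C)C3)n2)COc2ccccc21`) reads > 100000 nM, also only a limit, so its standing in this assay cannot be given as a number, and the other two values offer no number to set it against.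

Compound 4 (`CN1C(=S)[C@@H](NC(=O)c2nc(Cc3ccccc3)n(Cc3ccccc3)n2)COc2ccccc21`) has not yet been measured. It differs from compound 3 by one exchange, (a group of 7 heavy atoms (7 carbon; one six-membered aromatic ring of carbon only) in place of a group of 12 heavy atoms (9 carbon, 1 nitrogen, 2 oxygen; one five-membered non-aromatic ring with 1 hetero atom), on an aromatic nitrogen).

For the measured compounds named here, three measured steps bear on this exchange: a step that the two limits leave unreadable from compound 1 to compound 2, a step that the two limits leave unreadable from compound 1 to compound 3 and a step that the two limits leave unreadable from compound 2 to compound 3. None of them has a readable size. Going by the values given here, the only guide is the limit of > 100000 nM in this assay, at which 3 of the 3 values shown sit. On that basis, no step beyond the usual scatter is expected, and the estimated step is a number no higher from compound 3 to compound 4 (the limit leaves the size open). Compound 4 is expected at about 100000 nM, with an estimated range from 40000 nM to 200000 nM.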

Compound 4, half-maximal cytotoxic concentration: > 100000 nM
Compound 4: no number, only a limit; the forecaster's own chance of this, stated with the estimate: 85%; the middle value sits exactly at the limit.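

In this assay compound 4 gives > 100000 nM and this is a limit of the assay, not a number. For the compounds shown here, no step linking compound 4 to compound 1, compound 2 or compound 3 can be read. The compounds shown leave open whether any group on this aromatic nitrogen changes the read-out at all, because all they offer is one limit: the limit of > 100000 nM in this assay, at which 4 of the 4 values shown sit.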